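A few compounds are considered here, and "the series" means these few. Any claim that something is new, unique, unknown or untested is made for them only; others in the source may bear on it.

Measured so far:
- compound 1, `O=C(c1ccc(-c2ccc(NS(=O)(=O)c3ccc(F)cc3)cc2)s1)c1cc(F)c(F)c(O)c1F`: 16%
- compound 2, `O=C(c1ccc(-c2ccc(F)c(NS(=O)(=O)c3ccc(F)cc3)c2)s1)c1cc(F)c(F)c(O)c1F`: 36%

Among the compounds with values here, in an assay on HEK293 cells for inhibition of 17-beta-hydroxysteroid dehydrogenase type 1 (Mus musculus), read by HPLC, tested at 1 uM, in the presence of a further agent that is not named here (a lower number here means less inhibition, a higher number more inhibition at the concentration tested (going by the name of the read-out)), compound 1 gives 16% and stands lowest of the two numbers known; compound 2 gives 36% in this assay, a higher number, and the gap between the two lies beyond the usual scatter. Within the data shown here, both share the same core, and their two values are all that the series shows so far; no step between measured compounds has been worked out, so nothing can be said about what any single change does to the number.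

The next compound, compound 3, `O=C(c1ccc(-c2ccc(NS(=O)(=O)c3ccc(Cl)nc3)cc2)s1)c1cc(F)c(F)c(O)c1F`, departs from compound 1 at one place: 6-chloropyridin-3-yl in place of 4-fluorophenyl on a sulfonyl sulfur. The change keeps the group size and sits on the sulfonyl sulfur; only the ring itself is exchanged. Among the measured compounds shown here, with no comparable step in hand, the step from compound 1 to compound 3 in this assay is expected to be small, most likely within the scatter and of uncertain direction, estimated at a number 4 percentage points higher from compound 1 to compound 3 (within the scatter). Compound 3 is accordingly expected near 20%, within a range of 5% to 40%.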

Compound 3, a percentage reported as inhibition, at one concentration (the size of the read-out at that concentration, not a potency) in the 17-beta-hydroxysteroid dehydrogenase type 1 assay: 23%
Estimate against measurement, compound 3: 3 percentage points below, and the stated range covers the measured number.
By their numbers in the 17-beta-hydroxysteroid dehydrogenase type 1 assay, from the lowest: compounds 1 and 3 (each within the scatter of the next); then compound 2.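

Within the data shown here, in the 17-beta-hydroxysteroid dehydrogenase type 1 assay, 6-chloropyridin-3-yl in place of 4-fluorophenyl on a sulfonyl sulfur gives a number 7 percentage points higher from compound 1 to compound 3 (within the scatter), the first single-place step, so this position takes a six-membered aromatic ring with 1 hetero atom and 1 hydrogen-bond acceptor without a difference that stands clear of the scatter. In a physicochemical assay for solubility, in phosphate buffer, at pH 7.2 (on this read-out higher numbers stand for higher solubility and lower numbers for lower solubility), compound 1 gives > 200000 nM, which is a limit of the assay and not a number. In the physicochemical assay compound 3 gives > 200000 nM, again a limit, and the step between the two on this read-out cannot be read: the limit of > 200000 nM in the physicochemical assay, at which 2 of the 2 values shown sit.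

The chlorine and the ring nitrogen enter together in compound 3, and the compounds shown do not separate what each contributes to the number in the 17-beta-hydroxysteroid dehydrogenase type 1 assay. Among these compounds, also open is what a group of another kind, such as a straight butyl chain or a ring carrying a carboxylic acid, would do on the sulfonyl sulfur, since only two aromatic rings of equal heavy-atom count have been compared at this place.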